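The source may report more compounds than this note shows. Statements on the series, on what has been measured and on what is new or still open speak of the compounds shown alone.

In a functional assay on A549 cells (Homo sapiens) for inhibition (on this read-out lower numbers stand for stronger inhibition and higher numbers for weaker inhibition), compound 1 `COC(=O)C(C(=O)OC)C1CC(=O)C=CC12OCC(=O)N2Cc1ccc(C)cc1` gives 9250 nM. Sharing the core of compound 1 and carrying chloro in place of methyl on an aromatic carbon, compound 2 `COC(=O)C(C(=O)OC)C1CC(=O)C=CC12OCC(=O)N2Cc1ccc(Cl)cc1` gives 9980 nM. That exchange amounts to a 1.1-fold higher number from compound 1 to compound 2 (0.03 log units; within the scatter). Within the data shown here, compound 2 therefore stands level with compound 1, and the two numbers cannot be told apart of only two measurements.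

The next compound, compound 3 `COC(=O)C(C(=O)OC)C1CC(=O)C=CC12OCC(=O)N2Cc1ccc(Br)cc1`, keeps everything else and changes one atom: bromo in place of chloro on an aromatic carbon. This places bromo in place of chloro on an aromatic carbon, para to a large group, so the 4-chlorobenzyl becomes a 4-bromobenzyl. Among the measured compounds shown here, only one measured step bears on this change, the exchange at the same place from compound 1, a 1.1-fold higher number from compound 1 to compound 2 (0.03 log units; within the scatter). It is a single small step and offers no trend to extend, so no shift beyond the scatter is anticipated. The expected change is a 1.1-fold lower number from compound 2 to compound 3 (0.02 log units; within the scatter), which would remain within the scatter. Compound 3 is expected to give about 9500 nM, with an estimated range of 5000 nM to 18000 nM.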

Compound 3, half-maximal inhibitory concentration: 2550 nM
Compound 3: middle estimate off by 3.7-fold (0.57 log units), on the high side; the measured number lies below the stated range.
By their numbers in this assay, from the lowest: compound 3; then compounds 1 and 2 (each within the scatter of the next).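

Bromo in place of chloro on the aromatic carbon gives a 3.9-fold lower number from compound 2 to compound 3 (0.59 log units; beyond the scatter) in this assay, and bromo in place of methyl gives a 3.6-fold lower number from compound 1 to compound 3 (0.56 log units; beyond the scatter) on the same read-out. The earlier pair showed no separation, with a 1.1-fold higher number from compound 1 to compound 2 (0.03 log units; within the scatter), so only now is it clear that the group on this aromatic carbon, para to a large group, can move the number beyond the scatter, and compound 3 stands as the strongest inhibitor of the three. Nothing available here accounts for why bromo parts from chloro and methyl at this place.

As far as these compounds go, what remains open is whether this lower number belongs to bromo alone or would also appear with iodo, trifluoromethyl or methoxy in the same place, or with a plain unsubstituted benzyl. Three compounds that differ at a single place also cannot show whether the gain from bromo would hold if the two methyl esters of the shared core gave way to a carboxylic acid or an amide.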